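The compounds below may be only part of what the source reports. "The series", "measured", "known", "first", "only" and "open" are said of these compounds alone.

Of the compounds shown here, three have been measured in a physicochemical assay for lipophilicity, measured as octanol-water partition; on this read-out lower numbers stand for lower lipophilicity and higher numbers for higher lipophilicity. Compound 1 `CCO/N=C/Nc1cc(Cl)c(S(=O)(=O)CC)c(Cl)c1` gives 2.8 in this assay, compound 2 `CC#CCOc1c(Cl)cc(N/C=N/OCC)cc1Cl` gives 4, and compound 3 `C#CCc1c(Cl)cc(N/C=N/O)cc1Cl` gives 2.8. Compound 3 thus stands level with compound 1 at the digits given, and together they are the lowest of the three numbers; compound 2 lies a number 1.20 log units higher from compound 1 to compound 2 (beyond the scatter), a change brought about by (but-2-yn-1-yl)oxy in place of ethylsulfonyl on an aromatic carbon.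

Compound 4 `C#CCc1c(Cl)cc(N/C=N/OC/C=C\Cl)cc1Cl` has not yet been measured. It differs from compound 3 by 3-chloroprop-2-en-1-yl in place of hydrogen on an oxygen. Going by the values given here, no measured step changes this oxygen, so the only guide is the one step known, which is large and upward, and which also added a chain with no hydrogen-bond donors or acceptors. On that basis compound 4 is expected to read higher than compound 3, by about a number 1.50 log units higher from compound 3 to compound 4 (beyond the scatter). The estimate for compound 4 in this assay is 4.3, expected to fall between 3.7 and 4.9.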

Compound 4, partition coefficient: 3.9
Beside the measured number, compound 4's estimate is 0.40 log units above it; the measured number falls inside the stated range.
By their numbers in this assay, from the lowest: compounds 1 and 3 (each within the scatter of the next); then compounds 4 and 2 (each within the scatter of the next).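

In this assay, putting 3-chloroprop-2-en-1-yl in place of the hydrogen on this oxygen gives a number 1.10 log units higher from compound 3 to compound 4 (beyond the scatter). Going by these compounds alone, this is the first step at the oxygen whose other neighbour is the double-bonded nitrogen, and it shows that a change here, turning hydroxy into (3-chloroprop-2-en-1-yl)oxy, moves the read-out by a large amount, just as the earlier change on an aromatic carbon did. Nothing available bears on why this step has the size it has.

Open, going by these compounds, is how much of the step depends on the chlorine or the double bond, which a methyl group or a saturated propyl chain on the same oxygen would help to separate. Also open, on these data alone, is whether the same change gives a similar step on the core of compound 1.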